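The compounds below may be only part of what the source reports. "The series", "measured", "known", "first", "only" and "open" are said of these compounds alone.

Working notes on the series, read in a functional assay on KB-VIN10 cells (Homo sapiens) for inhibition, with a stated time of 72 h; a lower number here means a stronger inhibitor, a higher number a weaker inhibitor. In this assay compound 1 (`COc1ccc(S(=O)(=O)N2CCc3cccc(-c4ccc(F)c(F)c4)c32)cc1`) gives 46 nM, compound 2 (`COc1ccc(S(=O)(=O)N2CCc3cccc(-c4ccc(N(C)C)cc4)c32)cc1`) gives 553 nM and compound 3 (`COc1ccc(-c2cccc3c2N(S(=O)(=O)c2ccc(OC)cc2)CC3)cc1`) gives 352 nM. Compound 3 cannot be separated from compound 2, with a 1.6-fold lower number from compound 2 to compound 3 (0.20 log units; within the scatter). Both stand well above compound 1: 4-methoxyphenyl in place of 3,4-difluorophenyl gives a 7.7-fold higher number from compound 1 to compound 3 (0.88 log units; beyond the scatter), and 4-(dimethylamino)phenyl in its place gives a 12-fold higher number from compound 1 to compound 2 (1.08 log units; beyond the scatter).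

The next change leads to compound 4 (`COc1ccc(S(=O)(=O)N2CCc3cccc(-c4ccncc4)c32)cc1`): pyridin-4-yl in place of 4-methoxyphenyl on an aromatic carbon, with pyridin-4-yl in place of 4-methoxyphenyl on an aromatic carbon. For the measured compounds named here, no measured compound carries pyridin-4-yl, so the evidence is indirect. The step of a 7.7-fold higher number from compound 1 to compound 3 (0.88 log units; beyond the scatter) shows that exchanging the aryl group at this carbon can move the number well beyond the scatter. The step of a 1.6-fold lower number from compound 2 to compound 3 (0.20 log units; within the scatter) shows that one exchange there left it within the scatter. Compound 4 has lost the methoxy group of compound 3 but gained none of the fluorines of compound 1, so a small move toward a lower number is expected, with nothing beyond the scatter. The expected change is a 1.8-fold lower number from compound 3 to compound 4 (0.25 log units; within the scatter). Compound 4 is estimated at 200 nM, with an expected range of 60 nM to 650 nM.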

Compound 4, half-maximal inhibitory concentration: 106 nM
For compound 4 the middle estimate is 1.9-fold (0.28 log units) above the measured one; low and high end bracket the measured number.
By their numbers in this assay, from the lowest: compound 1; then compound 4; then compounds 3 and 2 (each within the scatter of the next).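

For the compounds shown here, at this aryl position in this assay, the step of a 3.3-fold lower number from compound 3 to compound 4 (0.52 log units; beyond the scatter) shows that pyridin-4-yl and 4-methoxyphenyl can be told apart, whereas the one exchange among the earlier substituted phenyl rings, between compound 2 and compound 3, stayed within the scatter. Pyridin-4-yl also stands clear of 4-(dimethylamino)phenyl, with a 5.2-fold lower number from compound 2 to compound 4 (0.72 log units; beyond the scatter) as the step, but it does not match 3,4-difluorophenyl, with a 2.3-fold higher number from compound 1 to compound 4 (0.36 log units; beyond the scatter) as the step, so compound 4 sets an intermediate level at this carbon, with compound 1 lower and compound 2 and compound 3 higher. Nothing measured on these compounds accounts for this order.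

Still open, from the compounds shown here alone, is whether the lower number of compound 4 relative to compound 3 goes with the ring nitrogen or with the loss of the methoxy group, a question that plain phenyl at this carbon would address. Also open, going by these compounds, is how far the result depends on where the nitrogen sits, as pyridin-3-yl would show, and whether a single fluorine, as in 4-fluorophenyl, would stay near compound 1.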